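The source may hold more compounds than are shown below. What is called first, only, known or untested is meant among the compounds shown, and "the series" means these compounds.

Measured so far in an ADME assay on the whole organism (Rattus norvegicus, strain Wistar Han) for pharmacokinetics, read by LC-MS, with a stated time of 7 h, at a dose of 1 mg/kg by the intravenous route (on this read-out higher numbers stand for fast clearance and lower numbers for slow clearance), are three compounds:

- compound 1 `CNC(=O)c1cc(C(=O)N[C@H]2[C@@H]3COC[C@@H]32)cc2c1OC[C@@]2(C)c1ccccc1` gives 61 mL/min/kg
- compound 2 `CNC(=O)c1cc(C(=O)NC2CC2)cc2c1OC[C@H]2c1ccccc1` gives 34 mL/min/kg
- compound 3 `CNC(=O)c1cc(C(=O)N[C@H]2C[C@@H]2C)cc2c1OC[C@@]2(CO)c1ccccc1` gives 60 mL/min/kg

Compound 1, at 61 mL/min/kg in this assay, lies within the usual scatter of both compound 3 and compound 2, so these three values do not separate the compounds.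

The next compound to be read is compound 4 `CNC(=O)c1cc(C(=O)N[C@H]2[C@@H]3C[C@@H](O)C[C@@H]32)cc2c1OC[C@@]2(C)c1ccccc1`, and the change from compound 1 is a group of 7 heavy atoms (6 carbon, 1 oxygen; one three-membered non-aromatic ring of carbon only, one five-membered non-aromatic ring of carbon only) in place of a group of 6 heavy atoms (5 carbon, 1 oxygen; one three-membered non-aromatic ring of carbon only, one five-membered non-aromatic ring with 1 hetero atom), on an amide-type nitrogen while the core of compound 1 stays as it is. The group that enters has a five-membered non-aromatic ring of carbon only, and the group that leaves has a five-membered non-aromatic ring with 1 hetero atom.

Among the measured compounds shown here, no two measured compounds differ in one place only, so no measured step speaks directly to this change. For the measured compounds named here, the only guide is that compound 3 at 60 mL/min/kg and compound 2 at 34 mL/min/kg stay within the scatter of compound 1 while carrying other groups on the amide-type nitrogen. No step beyond the scatter is therefore expected in this assay, and any shift is expected to be small. The estimated 1.4-fold lower number from compound 1 to compound 4 (0.13 log units; within the scatter) stays within the scatter. For compound 4 the expected value is 45 mL/min/kg with an estimated range of 22 mL/min/kg to 85 mL/min/kg for the coming measurement.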

Compound 4, clearance: 55 mL/min/kg
The estimate for compound 4 lay 1.2-fold (0.09 log units) below the measured number; the measured number falls inside the stated range.
By their numbers in this assay, from the lowest: compounds 2, 4, 3 and 1 (each within the scatter of the next).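

Among the compounds shown here, the first one-place comparison, on an amide-type nitrogen with the core of compound 1 unchanged, reads in this assay as a 1.1-fold lower number from compound 1 to compound 4 (0.04 log units; within the scatter). The entering group has a five-membered non-aromatic ring of carbon only and carries 1 hydrogen-bond donor, whereas the leaving group has a five-membered non-aromatic ring with 1 hetero atom and carries 0 hydrogen-bond donors, so on this core the exchange does not separate the two compounds in this read-out. No measurement at hand bears on why the two groups read alike.

Compound 2 and compound 3 differ from compound 1 and compound 4 in more than one place, so the steps to them cannot be read and the contributions of the amide-nitrogen group and the other changed site remain unseparated. From the compounds shown here alone, it remains open whether a primary amine, a carboxylic acid or a longer alkyl chain on this amide-type nitrogen would also stay within the scatter of compound 1, and whether the present exchange would read the same way on the core of compound 2 or compound 3.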